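The source may hold more compounds than are shown below. What is called first, only, known or untested is meant among the compounds shown, and "the series" means these compounds.

Compound 1, `O=C(/C=C/c1ccc([N+](=O)[O-])cc1)Nc1cc(Sc2ncn[nH]2)c(O)c2ccccc12`, was examined in an assay on isolated protein for inhibition of RAC-alpha serine/threonine-protein kinase (Homo sapiens), read by fluorescence, with a stated time of 30 min, tested at 10 uM (on this read-out higher numbers stand for more inhibition at the one concentration tested (going by the name of the read-out) and lower numbers for less inhibition), where compound 1 gives 40.6%. A second member of the series, compound 2, `O=C(Nc1cc(Sc2ncn[nH]2)c(O)c2ccccc12)c1ccc2ccccc2c1`, was also measured, and in this assay compound 2 gives 41.6%. Compound 1 thus stands at the lower of the two numbers, but the values of compound 1 and compound 2 lie within the scatter of each other, so nothing separates them. The unmeasured compound 3, `COc1ccc(/C=C/C(=O)Nc2cc(Sc3ncn[nH]3)c(O)c3ccccc23)cc1OC`, keeps the shared core and differs from compound 1 by a single change: 3,4-dimethoxyphenyl in place of 4-nitrophenyl on a double-bonded chain carbon bound to a double-bonded chain carbon. For the measured compounds named here, with no step between measured compounds available, the account expects the step from compound 1 to compound 3 to stay within the scatter, with a number 2.6 percentage points lower from compound 1 to compound 3 (within the scatter) as the anticipated shift. Compound 3 is therefore estimated to give about 38%, expected to fall between 20% and 56%.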

Compound 3, a percentage reported as inhibition, at one concentration (the size of the read-out at that concentration, not a potency): 31.7%
Estimate against measurement, compound 3: 6.3 percentage points above; low and high end bracket the measured number.
By their numbers in this assay, from the lowest: compounds 3, 1 and 2 (each within the scatter of the next).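

In this assay, the change at this position gives a number 8.9 percentage points lower from compound 1 to compound 3 (within the scatter), the only step shown that isolates a single place on the shared core. Exchanging 4-nitrophenyl for 3,4-dimethoxyphenyl on a double-bonded chain carbon bound to a double-bonded chain carbon therefore moves the read-out by no more than the usual scatter, even though the entering group has a different atom make-up, with no nitrogen and one heavy atom more. Nothing available explains the size of this step or connects it to either group.

The compounds shown leave open whether a different group at this place, such as an amine in the form of 4-aminophenyl or a carboxylic acid in the form of 4-carboxyphenyl, would move the number beyond the scatter of compound 1. They also leave open whether replacement of the aromatic ring at this position by a plain alkyl chain would leave the number higher, lower or level.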